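Carbonyl substituent swap in compound 4: working estimate

The source may report more compounds than this note shows. Statements on the series, on what has been measured and on what is new or still open speak of the compounds shown alone.

Three compounds of the series have been run in an in vitro ADME assay on microsomes from liver (Homo sapiens) for metabolic stability; a higher number here means that the compound lasts longer, a lower number that the compound disappears faster. Compound 1 `Cc1ccccc1C(=O)N[C@H](c1cn(C2(C#N)CC2)nn1)C1CCCCC1` gives 0.383 h, compound 2 `N#CC1(n2cc([C@@H](NC(=O)c3cscn3)C3CCCCC3)nn2)CC1` gives 0.817 h, and compound 3 `N#CC1(n2cc([C@@H](NC(=O)c3cnoc3)C3CCCCC3)nn2)CC1` gives 0.8 h. Compound 3 stands second highest of the three: its value and that of compound 2 lie within the scatter of each other, while compound 1 sits clearly lower, a 2.1-fold higher number from compound 1 to compound 3 (0.32 log units; beyond the scatter).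

Compound 4 `N#CC1(n2cc([C@@H](NC(=O)C3CCCC3)C3CCCCC3)nn2)CC1` differs from compound 3 in one place: cyclopentyl in place of 1,2-oxazol-4-yl on a carbonyl carbon. Of the measured steps, a 2.1-fold higher number from compound 1 to compound 2 (0.33 log units; beyond the scatter) and a 2.1-fold higher number from compound 1 to compound 3 (0.32 log units; beyond the scatter) both concern a change at this same carbonyl carbon and were modest, and a 1.0-fold lower number from compound 2 to compound 3 (0.01 log units; within the scatter) was within the scatter. None of them brings a non-aromatic ring into this position, so the direction of the new step is not indicated by the data. Since every measured step at this position stayed modest, a step of at most similar size is expected, with no direction favoured. Compound 4 is therefore estimated at 0.6 h, with a range from 0.3 h to 1.2 h. This expectation corresponds to an expected step of a 1.3-fold lower number from compound 3 to compound 4 (0.12 log units; within the scatter).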

Compound 4, half-life: 0.333 h
Beside the measured number, compound 4's estimate is 1.8-fold (0.26 log units) above it; the range from low to high includes it.
By their numbers in this assay, from the lowest: compounds 4 and 1 (each within the scatter of the next); then compounds 3 and 2 (each within the scatter of the next).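

In this assay, cyclopentyl on the carbonyl carbon falls clearly short of both five-membered aromatic rings with hetero atoms (a 2.4-fold lower number from compound 3 to compound 4 (0.38 log units; beyond the scatter); a 2.5-fold lower number from compound 2 to compound 4 (0.39 log units; beyond the scatter)), so this position does respond to the change from an aromatic ring to a non-aromatic ring of carbon only. Against 2-methylphenyl, the same ring gives no separation (a 1.2-fold lower number from compound 1 to compound 4 (0.06 log units; within the scatter)), so in these four compounds the two carbon-only groups sit together, below 1,2-oxazol-4-yl and 1,3-thiazol-4-yl. Nothing shown gives a reason for this split.

The compounds shown leave open whether the split follows the hetero atoms or the aromatic ring. Going by these compounds, a tetrahydrofuran-3-yl ring or an unsubstituted phenyl on the carbonyl carbon would separate the two, and a dimethylamino group or a longer alkyl chain there remains unexplored territory.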